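The source may hold more compounds than are shown below. What is called first, only, known or untested is meant among the compounds shown, and "the series" means these compounds.

Compound 1 `CCCCCCCCCC(=O)OCC1CN(C(=O)c2cc(OC)c(OC)c(OC)c2)CCN1C(=O)c1cc(OC)c(OC)c(OC)c1` is the reference point for this step. In a functional assay (Oryctolagus cuniculus) for inhibition of platelet-activating factor receptor (Cavia porcellus) (on this read-out higher numbers stand for weaker inhibition and lower numbers for stronger inhibition), compound 1 gives 2820 nM, the second highest of the three numbers at hand. Compound 2 `CCCCCCCCCCCCCCCCCC(=O)OCC1CN(C(=O)c2cc(OC)c(OC)c(OC)c2)CCN1C(=O)c1cc(OC)c(OC)c(OC)c1`, which carries a longer acyl chain on the same core, gives 45000 nM. Compound 3 `CCC(CC)C(=O)OCC1CN(Cc2cc(OC)c(OC)c(OC)c2)CCN1Cc1cc(OC)c(OC)c(OC)c1` differs from compound 1 both in the ester chain and in the links from the core to the two aryl groups; compound 3 gives 2700 nM. For the measured compounds named here, this number and that of compound 1 lie within the scatter of each other, and no single step connects the two.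

Compound 4 `CCCC(C)NC(=O)OCC1CN(C(=O)c2cc(OC)c(OC)c(OC)c2)CCN1C(=O)c1cc(OC)c(OC)c(OC)c1` has not been measured. Relative to compound 1 the change is (1-methylbutyl)amino in place of nonyl on a carbonyl carbon, the ester becoming a carbamate. Going by the values given here, the one measured step that bears on it is a 16-fold higher number from compound 1 to compound 2 (1.20 log units; beyond the scatter): lengthening the chain by octyl weakened inhibition strongly, so moving the other way, to a smaller group on the carbonyl carbon, is not expected to cost potency. Whether it gains anything is not shown, since compound 3 carries a second change of its own. Compound 4 is therefore expected to land close to compound 1, and the expected step is a 1.4-fold lower number from compound 1 to compound 4 (0.15 log units; within the scatter). The estimate for compound 4 is 2000 nM, with a range from 700 nM to 6000 nM.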

Compound 4, half-maximal inhibitory concentration: 100 nM
Beside the measured number, compound 4's estimate is 20-fold (1.30 log units) above it; measured number outside the range, below it.
By their numbers in this assay, from the lowest: compound 4; then compounds 3 and 1 (each within the scatter of the next); then compound 2.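

In this assay, for the compounds shown here, the change on this carbonyl carbon from nonyl to (1-methylbutyl)amino gives a 28-fold lower number from compound 1 to compound 4 (1.45 log units; beyond the scatter) and turns the ester into a carbamate, showing that this position can support much stronger inhibition than the acyl chains suggested; the only earlier step here, a 16-fold higher number from compound 1 to compound 2 (1.20 log units; beyond the scatter), showed only a loss on lengthening the chain. The new step bundles several differences, as the group on the carbonyl carbon goes from 9 heavy atoms to 6, gains a branch and a nitrogen, and adds 1 hydrogen-bond donor, so the gain cannot be assigned to any one of them. The data at hand offer no measured basis for explaining the size of this gain.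

Still open, as far as these compounds go, is whether the gain follows the nitrogen or the shorter branched chain: an unbranched pentylamino group and a 1-methylbutyl group joined through carbon, both on the same core, would help separate the two. Also open, from the compounds shown here alone, is whether a longer alkyl chain on the carbamate nitrogen weakens inhibition as the octyl extension did on the ester.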